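The source may hold more compounds than are shown below. What is called first, only, known or untested is meant among the compounds shown, and "the series" means these compounds.

Measured in a functional assay on HL-60 cells (Homo sapiens) for inhibition; a lower number here means a stronger inhibitor, a higher number a weaker inhibitor:
- Compound 1 `COc1cc(/C=C/c2cn(C(C)=O)c3ccccc23)cc(OC)c1OC`: > 5000 nM, a limit of the assay and not a number.
- Compound 2 `COc1cc(/C=C/c2c[nH]c3ccccc23)cc(OC)c1OC`: 3230 nM

Going by the values given here, compound 2, at 3230 nM, holds the only actual number so far, so it cannot yet be ranked within a spread of numbers. Compound 3 `COc1cc(/C=C/c2cn(C)c3ccccc23)cc(OC)c1OC` differs from compound 2 by one change: methyl in place of hydrogen on an aromatic nitrogen.

One measured step also concerns an aromatic nitrogen: an at least 1.5-fold lower number from compound 1 to compound 2 (0.18 log units; that floor lies within the scatter), with hydrogen in place of acetyl. Its floor lies within the scatter and it involves a different group, so it is only a weak guide. No step beyond the scatter is therefore expected in this assay, in either direction. The expected step is a 1.0-fold lower number from compound 2 to compound 3 (0.00 log units; within the scatter). For compound 3, the estimated value is 3200 nM, with an expected range from 1400 nM to 5000 nM.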

Compound 3, half-maximal inhibitory concentration: 3090 nM
Compound 3: middle estimate off by 1.0-fold (0.02 log units), on the high side; low and high end bracket the measured number.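

Swapping hydrogen for methyl on the aromatic nitrogen gives the first comparison at this position between two actual numbers, and in this assay the two groups cannot be told apart: a 1.0-fold lower number from compound 2 to compound 3 (0.02 log units; within the scatter). The hydrogen on this nitrogen is therefore not required to keep this level of inhibition, at least for compound 3. Methyl in place of acetyl reads as an at least 1.6-fold lower number from compound 1 to compound 3 (0.20 log units; that floor lies within the scatter), and this pair does not separate the two groups, since compound 1 carries a limit of the assay and not a number: the limit of > 5000 nM in this assay, at which 1 of the 3 values shown sits.

The compounds shown leave open whether any group on this nitrogen can move the number beyond the scatter, for instance a longer chain, a benzyl group or a chain ending in an amine. They also leave open whether changes elsewhere on the shared core can give stronger inhibition.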